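The compounds below may be only part of what the source reports. "The series", "measured", "known", "first", "only" and "open" are said of these compounds alone.

Compound 1 `C/C(=N\NC(N)=O)c1ccc2[nH]c(-c3ccc(Cl)cc3)nc2c1` gives > 100000 nM in an ADME assay on BHK-21 cells (Mesocricetus auratus) for cytotoxicity, read by MTT assay (on this read-out lower numbers stand for higher toxicity in this test and higher numbers for lower toxicity in this test), which is a limit of the assay rather than a number.
Compound 2 `C/C(=N\NC(N)=S)c1ccc2[nH]c(-c3ccc(Cl)cc3)nc2c1` gives > 100000 nM in this assay, again a limit of the assay.
Compound 3 `C/C(=N\NC(N)=O)c1ccc2c(c1)nc(-c1ccccc1)n2C1CCCCC1` gives > 100000 nM in this assay, also a limit of the assay.

All three measured compounds therefore sit at the same edge of what this assay can report, as the limit of > 100000 nM in this assay, at which 3 of the 3 values shown sit, records. Compound 1 and compound 2 differ in one place only: a group of 3 heavy atoms (1 carbon, 1 nitrogen, 1 sulfur; no ring) in place of a group of 3 heavy atoms (1 carbon, 1 nitrogen, 1 oxygen; no ring), on an amine nitrogen. The step between them, a step that the two limits leave unreadable from compound 1 to compound 2, cannot be read, since both values are limits and no number stands on either side. For the measured compounds named here, compound 3 carries a different core from compound 1; the difference between the two cores is not broken down here, and their two limits show only that neither compound reached a measurable value.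

Compound 4 `C/C(=N\NC(N)=S)c1ccc2c(c1)nc(-c1ccccc1)n2C1CCCCC1` has not yet been measured. It stands to compound 3 exactly as compound 2 stands to compound 1: a group of 3 heavy atoms (1 carbon, 1 nitrogen, 1 sulfur; no ring) in place of a group of 3 heavy atoms (1 carbon, 1 nitrogen, 1 oxygen; no ring), on an amine nitrogen. The surroundings of the change are the same in both pairs, so this is the same change made on the other core.

In this assay the step from compound 3 to compound 4 is expected to be small, a step that the limit leaves unreadable from compound 3 to compound 4, because both members of the matching pair, compound 1 and compound 2, sit at the limit of > 100000 nM in this assay, at which 3 of the 3 values shown sit. Compound 4 is therefore expected to give about 150000 nM, with the likely range running from 60000 nM to 400000 nM, and most probably the assay will again report only a limit.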

Compound 4, half-maximal cytotoxic concentration: 38000 nM
Beside the measured number, compound 4's estimate is 3.9-fold (0.60 log units) above it; measured number outside the range, below it.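

In this assay, replacing the carbamoyl group with the matching group that carries sulfur in place of oxygen, on the same amine nitrogen, gives an at least 2.6-fold lower number from compound 3 to compound 4 (0.42 log units; beyond the scatter), and since a lower number stands for higher toxicity in this test, the sulfur group goes with more toxicity on this core. Compound 3 reports only a limit, so this step gives the least the change can amount to, and its true size may be larger. This does not show that the change carries from one core to another, since the matching step from compound 1 to compound 2 cannot be read and nothing can be said about whether the change does the same, or anything at all, on that core, because both compounds sit at the edge of what the assay reports: the limit of > 100000 nM in this assay, at which 3 of the 4 values shown sit.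

The compounds shown leave open how the change behaves on any core other than these two, and whether a core on which both members of the pair give real numbers would show a step of similar size. They also leave open what a carboxylic acid or a longer chain would do in place of the carbamoyl group on that amine nitrogen.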